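Replacing the methoxy group of compound 2

The compounds below may be only part of what the source reports. "The series", "measured", "known", "first", "only" and "open" are said of these compounds alone.

Measured in a functional assay on HEp-2 cells (Homo sapiens) for inhibition; a higher number here means that more compound is needed for the effect, a lower number that less compound is needed:
- Compound 1 `CSc1ncnc2nn([C@@H]3O[C@H](COC(C)=O)[C@@H](OC(C)=O)[C@H]3OC(C)=O)nc12`: 7 uM
- Compound 2 `COc1ncnc2c1nnn2[C@@H]1O[C@H](CO)[C@@H](O)[C@H]1O`: 0.3 uM

Compound 2 holds the lower of the two numbers, at 0.3 uM, so less of it is needed for the effect. The gap to compound 1, at 7 uM, lies beyond the scatter. These two compounds differ in more than one place, however, so their gap cannot be tied to any single change.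

The next compound to be measured is compound 3 `CC(C)=CCNc1ncnc2c1nnn2[C@@H]1O[C@H](CO)[C@@H](O)[C@H]1O`. It keeps the shared core of compound 2 and changes one group: (3-methylbut-2-en-1-yl)amino in place of methoxy on an aromatic carbon. The new group, (3-methylbut-2-en-1-yl)amino, sits in the same place as the methoxy, on an aromatic carbon next to the ring nitrogen.

For the measured compounds named here, no measured pair shows what this exchange does, so any forecast is uncertain. Going by the values given here, compound 2 is the lower of only two numbers, and a moderate rise beyond the scatter is expected, though a wide range stays open. The expected size of the change is an 8.3-fold higher number from compound 2 to compound 3 (0.92 log units; beyond the scatter). For compound 3 the estimated value is 2.5 uM, with an expected range from 0.3 uM to 20 uM.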

Compound 3, concentration for half-maximal effect: < 3 uM
Compound 3 ended at the assay's limit; the forecaster's own chance of this, stated with the estimate: 15%; the middle value does not contradict the limit.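

In this assay compound 3 gives < 3 uM, which is a limit of the assay and not a number. The step between compound 2 and compound 3 cannot be read. The compounds shown leave open what exchanging methoxy for (3-methylbut-2-en-1-yl)amino does in this assay, including whether the number rises, falls or stays within the scatter.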